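A few compounds are considered here, and "the series" means these few. Any claim that something is new, unique, unknown or untested is made for them only; others in the source may bear on it.

Working notes on the series.

Compound 3 `O=C(Nc1cccc(S(=O)(=O)N2CCCC2)c1)C1CCCN(C(=O)c2cc(C(F)(F)F)cc(C(F)(F)F)c2)C1` carries the shared core of the series with a (pyrrolidin-1-yl)sulfonyl group on the aromatic carbon. In an ADME assay on PC-3 cells (Homo sapiens) for cytotoxicity, read by WST assay, tested at 100 uM (a higher number here means more inhibition at the concentration tested (going by the name of the read-out), a lower number less inhibition), compound 3 gives 0%. It stands level with compound 1 `COC(=O)c1cccc(NC(=O)C2CCCN(C(=O)c3cc(C(F)(F)F)cc(C(F)(F)F)c3)C2)c1`, which in this assay gives 0%; together these are the lowest of the three numbers. Compound 2 `O=C(Nc1cccc(Oc2ccccc2)c1)C1CCCN(C(=O)c2cc(C(F)(F)F)cc(C(F)(F)F)c2)C1` in this assay gives 1%. The three measured steps are all small: a number 1 percentage points higher from compound 1 to compound 2 (within the scatter), no change at the digits printed from compound 1 to compound 3 (within the scatter) and a number 1 percentage points lower from compound 2 to compound 3 (within the scatter). For the measured compounds named here, nothing among the three measured compounds shows a difference beyond the scatter; the series so far reads as flat at the concentration tested.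

Compound 4 `O=C(Nc1cccc(-c2cnco2)c1)C1CCCN(C(=O)c2cc(C(F)(F)F)cc(C(F)(F)F)c2)C1` differs from compound 3 by 1,3-oxazol-5-yl in place of (pyrrolidin-1-yl)sulfonyl on an aromatic carbon. Going by the values given here, the steps that bear on this change are those that swapped the substituent on the same aromatic carbon, from compound 1 to compound 3 and from compound 2 to compound 3, and both stayed within the scatter, as did the step from compound 1 to compound 2. On that basis the expected step is a number 2 percentage points higher from compound 3 to compound 4 (within the scatter), none beyond the scatter, in no particular direction. Compound 4 is therefore estimated at 2% in this assay, with a range from -6% to 12%.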

Compound 4, a percentage reported as inhibition, at one concentration (the size of the read-out at that concentration, not a potency): 9%
Compound 4: the middle estimate sits 7 percentage points below what was measured; low and high end bracket the measured number.
By their numbers in this assay, from the lowest: compounds 1, 3, 2 and 4 (each within the scatter of the next).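

In this assay the change to 1,3-oxazol-5-yl on this aromatic carbon gives a number 9 percentage points higher from compound 3 to compound 4 (within the scatter) and a number 8 percentage points higher from compound 2 to compound 4 (within the scatter) and also a number 9 percentage points higher from compound 1 to compound 4 (within the scatter) as the third reading of the same swap. This extends the flat picture at this position to a five-membered aromatic ring with 2 hetero atoms: four different groups have now stood on this carbon, from methoxycarbonyl and phenoxy to (pyrrolidin-1-yl)sulfonyl and 1,3-oxazol-5-yl, and no step among those shown leaves the scatter, so the four compounds cannot be placed in any order. No measurement is available that would account for where the reading of compound 4 falls.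

Still open, from the compounds shown here alone, is whether a group of another kind on this aromatic carbon, such as an amine or a carboxylic acid, would produce a step beyond the scatter at the concentration tested. Also open, going by these compounds, is whether other five-membered aromatic rings, such as a 1,3-thiazol-5-yl or an imidazolyl ring, would read like 1,3-oxazol-5-yl, and whether changes elsewhere on the shared core would move the number at all.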